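The source may hold more compounds than are shown below. What is called first, only, known or untested is meant among the compounds shown, and "the series" means these compounds.

Compound 1 `O=C(CN1CCN(c2nnc(Cc3ccncc3)c3ccccc23)CC1)Nc1cccc(F)c1` is the most potent of the three measured compounds in a functional assay on MDA-MB-231 cells (Homo sapiens) for cytotoxicity, read by MTT assay, with a stated time of 72 h (a lower number here means a stronger inhibitor, a higher number a weaker inhibitor), with a value of 4.4 nM, far from its nearest neighbour compound 3 `O=C(CN1CCN(c2nnc(Cc3ccccc3)c3ccccc23)CC1)Nc1ccc(F)c(F)c1` at 2750 nM and further still from compound 2 `Cc1ccc(F)cc1NC(=O)CN1CCN(c2nnc(Cc3ccccc3)c3ccccc23)CC1` at 19200 nM. Among the compounds with values here, the one measured step that changes only the group on the amide-type nitrogen, from compound 2 to compound 3, reads a 7.0-fold lower number from compound 2 to compound 3 (0.84 log units; beyond the scatter), showing that the fluorine pattern on that ring alone shifts the value well beyond the scatter. Compound 4 `O=C(CN1CCN(c2nnc(Cc3ccncc3)c3ccccc23)CC1)Nc1c(F)cccc1F` makes a change in the same place on compound 1: 2,6-difluorophenyl in place of 3-fluorophenyl on an amide-type nitrogen. Within the data shown here, no measured pair shares this exact change, and the two compounds that carry a differently substituted amide aryl group, compound 2 and compound 3, also differ from compound 1 elsewhere in the core, so the direction can only be expected loosely. Because compound 1 stands at 4.4 nM, with little room to go lower, compound 4 is estimated to land somewhat weaker, at 30 nM within 5 nM to 300 nM, a step of a 6.8-fold higher number from compound 1 to compound 4 (0.83 log units; beyond the scatter).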

Compound 4, half-maximal inhibitory concentration: 1900 nM
Compound 4: the middle estimate sits 63-fold (1.80 log units) below what was measured; measured number above the stated range.
By their numbers in this assay, from the lowest: compound 1; then compounds 4 and 3 (each within the scatter of the next); then compound 2.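

In this assay, the group on the amide-type nitrogen proves decisive for compound 1: 2,6-difluorophenyl in place of 3-fluorophenyl gives a 430-fold higher number from compound 1 to compound 4 (2.64 log units; beyond the scatter), a large step. This exceeds the earlier change at the same nitrogen on the other core, a 7.0-fold lower number from compound 2 to compound 3 (0.84 log units; beyond the scatter), and shows that the shared core of compound 1 and compound 4 does not by itself secure the low number. Nothing available explains why this exchange costs so much.

The compounds shown leave open whether the step follows from the 2,6-difluorophenyl pattern as a whole or from one of its fluorines, which 2-fluorophenyl or 3-chlorophenyl on the same nitrogen would help to separate. They also leave open how an unsubstituted phenyl group would read on the core of compound 1.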